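A few compounds are considered here, and "the series" means these few. Any claim that something is new, unique, unknown or untested is made for them only; others in the source may bear on it.

Compounds with results: compound 1 `CO[C@@H]1[C@@H](OC)[C@H](c2ccccc2)O[C@@H]2CO[C@@H](c3ccco3)O[C@@H]12`, "not determined" (no result reported) in a functional assay on HEL cells (Homo sapiens) for cytotoxicity; a higher number here means that more compound is tolerated, a lower number that less compound is tolerated; compound 2 `COc1ccc([C@@H]2OC[C@H]3O[C@@H](c4ccccc4)[C@H](OC)[C@@H](OC)[C@@H]3O2)cc1`, "not determined" (no result reported) in this assay; compound 3 `CO[C@@H]1[C@@H](OC)[C@H](c2ccccc2)O[C@@H]2CO[C@@H](c3ccc(C(F)(F)F)cc3)O[C@@H]12`, >= 16 ug/mL in this assay.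

Only compound 3 carries a reading in this assay. That reading is a limit of the assay rather than a number: compound 3 gives >= 16 ug/mL, which is the point at which the measurement stops (the limit of >= 16 ug/mL in this assay, at which 1 of the 3 values shown sits). Among the compounds with values here, compound 1 and compound 2 have no result at all, so compound 3 stands alone, and no step between measured compounds can be drawn.

The unmeasured compound 4 `CO[C@@H]1[C@@H](OC)[C@H](c2ccccc2)O[C@@H]2CO[C@@H](c3ccc4ccccc4c3)O[C@@H]12` differs from compound 3 in one place (naphthalen-2-yl in place of 4-(trifluoromethyl)phenyl on a saturated ring carbon). Within the data shown here, because the only reading available is the limit reported for compound 3 >= 16 ug/mL, there is no measured change from which to judge how far a replacement of this kind moves the minimum cytotoxic concentration. The expectation is therefore a step of no more than the scatter, with no direction favoured, and with a fair chance that compound 4 also sits at the limit rather than at a single number.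

On that basis compound 4 is expected to give about 16 ug/mL in this assay, within a range from 8 ug/mL to 32 ug/mL, corresponding to an estimated step of a number no higher from compound 3 to compound 4 (the limit leaves the size open).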

Compound 4, minimum cytotoxic concentration: >= 16 ug/mL
Compound 4: no number, only a limit; the forecaster's own chance of this, stated with the estimate: 55%; the middle value lies on the limit itself.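

Compound 3 and compound 4 both sit at a limit of this assay rather than at a number, so no step between them can be read: the limit of >= 16 ug/mL in this assay, at which 2 of the 4 values shown sit.

The compounds shown leave open whether naphthalen-2-yl in place of 4-(trifluoromethyl)phenyl changes the minimum cytotoxic concentration at all, and in which direction.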